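Three quinazoline thioethers at the assay limit and a nitrophenyl change

The source may report more compounds than this note shows. Statements on the series, on what has been measured and on what is new or still open speak of the compounds shown alone.

Compound 1, `CCCCCCCCCCCCNc1nc(SCc2ccc(C(F)(F)F)cc2)nc2ccccc12`: in a functional assay on MGC-803 cells (Homo sapiens) for cytotoxicity, read by MTT assay, with a stated time of 72 h (on this read-out higher numbers stand for weaker inhibition and lower numbers for stronger inhibition), compound 1 gives > 50000 nM, a limit of the assay and not a number.
Compound 2, `CCCCCCCCCCCCCCNc1nc(SCc2ccc(C(F)(F)F)cc2)nc2ccccc12`: in this assay compound 2 gives > 50000 nM, likewise a limit.
Compound 3, `FC(F)(F)c1ccc(CSc2nc(Nc3ccccc3Cl)c3ccccc3n2)cc1`: in this assay compound 3 gives > 50000 nM, again a limit.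

Compound 3 therefore stands at the limit of > 50000 nM in this assay, at which 3 of the 3 values shown sit; all three values known here are limits, so it cannot be placed relative to compounds 1 and 2. Going by the values given here, the one step that can be formed, a step that the two limits leave unreadable from compound 1 to compound 2, is unreadable, as both of its ends are limits.

Compound 4, `O=[N+]([O-])c1cccc(Nc2nc(SCc3ccc(C(F)(F)F)cc3)nc3ccccc23)c1`, differs from compound 3 by 3-nitrophenyl in place of 2-chlorophenyl on a nitrogen on an aromatic ring. Among the compounds with values here, no measured step bears on this change: the only step known concerns a saturated chain, and it gives no size. What the data do show is that three compounds sharing the core, with two different amine substituents, all sit at the limit, and nothing argues that compound 4 should leave it.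

Compound 4 is therefore expected to sit near 60000 nM, with a range from 20000 nM to 200000 nM, and most likely to be reported again only as a limit. The step that the limit leaves unreadable from compound 3 to compound 4 is expected to be no more than scatter.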

Compound 4, half-maximal inhibitory concentration: > 50000 nM
Compound 4 ended at the assay's limit; the forecaster's own chance of this, stated with the estimate: 80%; the middle value is on the limit's open side.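

No step can be read from compound 3 to compound 4, since the values of both in this assay are limits of the assay and not numbers: the limit of > 50000 nM in this assay, at which 4 of the 4 values shown sit.

The compounds shown leave open how far each lies from that limit, and whether any change on the shared core would give a value readable as a number.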